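Ester chain change on a dihydropyridine core

The source may hold more compounds than are shown below. What is called first, only, known or untested is meant among the compounds shown, and "the series" means these compounds.

The measured compounds are compound 1, `CSc1ncc(C2C(C(=O)OC(C)C)=C(C)NC(C)=C2C(=O)OC(C)C)n1Nc1ccccc1`, with 2.16 nM in an assay on isolated protein (strain albino) for antagonist activity at Voltage-dependent L-type calcium channel subunit alpha-1C (Cavia porcellus); on this read-out higher numbers stand for weaker inhibition and lower numbers for stronger inhibition; compound 2, `COCCOC(=O)C1=C(C)NC(C)=C(C(=O)OC)C1c1cnc(SC)n1Nc1ccccc1`, with 9.65 nM in this assay; and compound 3, `CCOC(=O)C1=C(C)NC(C)=C(C(=O)OC(C)C)C1c1cnc(SC)n1Nc1ccccc1`, with 3.22 nM in this assay.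

Among these three numbers compound 3 stands second highest. Its nearest neighbour is compound 1, and the step of a 1.5-fold higher number from compound 1 to compound 3 (0.17 log units; within the scatter) lies within the scatter; its furthest neighbour is compound 2, whose number is higher by a margin beyond the scatter.

Compound 4, `COCCOC(=O)C1=C(C)NC(C)=C(C(=O)OC(C)C)C1c1cnc(SC)n1Nc1ccccc1`, is not yet measured. It differs from compound 3 by methoxy in place of hydrogen on a saturated chain carbon, two bonds along the chain from an oxygen next to a carbonyl group. Among the measured compounds shown here, only one measured step touches the same ester, and that is a 1.5-fold higher number from compound 1 to compound 3 (0.17 log units; within the scatter), a small change. Compound 2 also carries the 2-methoxyethyl ester but differs from compound 4 at the other ester as well, so its value gives a direction rather than a size. The expectation is therefore a modest rise in number, a 1.6-fold higher number from compound 3 to compound 4 (0.19 log units; within the scatter), with compound 2 marking the upper region. For compound 4 the estimate in this assay is 5 nM, with a range from 2 nM to 12 nM.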

Compound 4, half-maximal inhibitory concentration: 53.4 nM
Compound 4: the middle estimate sits 11-fold (1.03 log units) below what was measured; measured number above the stated range.
By their numbers in this assay, from the lowest: compounds 1 and 3 (each within the scatter of the next); then compound 2; then compound 4.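

In this assay, among the compounds shown here, the ester chain proves far more sensitive than the earlier compounds suggested: ethyl to 2-methoxyethyl gives a 17-fold higher number from compound 3 to compound 4 (1.22 log units; beyond the scatter), whereas the only earlier step at this ester, a 1.5-fold higher number from compound 1 to compound 3 (0.17 log units; within the scatter), stayed within the scatter. Replacing isopropyl directly with 2-methoxyethyl on an oxygen next to a carbonyl group gives a similarly large step, a 25-fold higher number from compound 1 to compound 4 (1.39 log units; beyond the scatter), so both measured routes to the 2-methoxyethyl ester with the isopropyl ester retained at the other end end in a clear rise in the number. The other ester also matters when the 2-methoxyethyl ester is present, since isopropyl in place of methyl there gives a 5.5-fold higher number from compound 2 to compound 4 (0.74 log units; beyond the scatter), a change that compound 2 alone could not reveal.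

The compounds shown leave open whether this rise follows from the methoxy group itself or from the longer chain, which a plain butyl ester, a 2-hydroxyethyl ester or a 2-aminoethyl ester could help separate. Nothing available here explains the size of these steps.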